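Swapping the aryl group on the amide of compound 2

The compounds below may be only part of what the source reports. "The series", "measured", "known", "first", "only" and "open" are said of these compounds alone.

In a functional assay on NCI-H1299 cells (Homo sapiens) for inhibition, read by CCK-8 assay, with a stated time of 72 h, tested at 1 uM (a lower number here means less inhibition of growth, a higher number more inhibition of growth at the concentration tested), compound 2 `CN(C)C(=O)c1cc2cnc(Nc3ccc(NC(=O)C4(C(=O)Nc5ccc(Cl)c(C(F)(F)F)c5)CC4)cc3)nc2n1C1CCCC1` gives 39.5%, the lower of the two numbers, while compound 1 `CN(C)C(=O)c1cc2cnc(Nc3ccc(NC(=O)C4(C(=O)Nc5cccc(F)c5)CC4)cc3)nc2n1C1CCCC1` gives 64.2%. Compound 3 `CN(C)C(=O)c1cc2cnc(Nc3ccc(NC(=O)C4(C(=O)Nc5cccc(Br)c5)CC4)cc3)nc2n1C1CCCC1` has 3-bromophenyl in place of 4-chloro-3-(trifluoromethyl)phenyl on an amide-type nitrogen. For the measured compounds named here, only one measured step bears on this place: a number 24.7 percentage points lower from compound 1 to compound 2 (beyond the scatter), beyond the scatter, on going from 3-fluorophenyl to the same 4-chloro-3-(trifluoromethyl)phenyl. Part of that step is expected to be recovered, which gives an expected rise of a number 16.5 percentage points higher from compound 2 to compound 3 (beyond the scatter). For compound 3 the estimated value is 56%, with an expected range from 40% to 72%.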

Compound 3, percent growth inhibition at one concentration: 46.6%
Beside the measured number, compound 3's estimate is 9.4 percentage points above it; low and high end bracket the measured number.
By their numbers in this assay, from the lowest: compounds 2 and 3 (each within the scatter of the next); then compound 1.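

In this assay, 3-bromophenyl in place of 4-chloro-3-(trifluoromethyl)phenyl on the amide-type nitrogen gives a number 7.1 percentage points higher from compound 2 to compound 3 (within the scatter), so these two aryl groups are not separated in this read-out. Bromo in place of fluoro on an aromatic carbon gives a number 17.6 percentage points lower from compound 1 to compound 3 (beyond the scatter), which shows that exchanging one halogen is enough to give a step beyond the scatter, without the added chloro and trifluoromethyl pattern. No measurement here explains either step. From the compounds shown here alone, it remains open how an unsubstituted phenyl, or a phenyl carrying an amine or a carboxylic acid, would read in this assay.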